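This account rests on a few compounds, and the source may have more. Where it says the series, first, only, none or still open, it means among the compounds named here.

Compound 1 `CC(=O)Nc1cccc(C2CCN(CCCC(=O)c3ccc(Cl)cc3)CC2)c1` is the starting point of this small set. In a functional assay on HEK293 cells for antagonist activity at melanin-concentrating hormone receptor 1 (Rattus norvegicus), read by FLIPR (a lower number here means a stronger inhibitor, a higher number a weaker inhibitor), compound 1 gives 570 nM. Compound 2 `O=C(CCCN1CCC(c2cccc(NC(=O)C3CCCCC3)c2)CC1)c1ccc(Cl)cc1` carries a cyclohexyl amide in place of the acetamide, but for compound 2 the outcome in this assay is recorded as "not determined" (no result reported), so no number is available for it. Compound 3 `CC(C)C(=O)Nc1cccc(C2CCN(Cc3cccc(Oc4ccc(Cl)cc4)c3)CC2)c1` changes the chain on the piperidine nitrogen to a benzyl group that bears a 4-chlorophenoxy substituent; in this assay compound 3 gives 2000 nM. Among the compounds with values here, of the two numbers known, that of compound 3 is the higher one, and the gap to compound 1 is wider than the scatter of repeated runs, so compound 3 is the weaker inhibitor of the two.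

Compound 4 `CC(C)C(=O)Nc1cccc(C2CCN(Cc3cccc(Oc4cc(Cl)cc(Cl)c4)c3)CC2)c1` differs from compound 3 in a single place: 3,5-dichlorophenyl in place of 4-chlorophenyl on an oxygen on an aromatic ring. Within the data shown here, no measured pair in this set tracks a change of this kind, so there is nothing to lean on beyond the value of compound 3 itself. The expectation for the step is therefore a 1.3-fold lower number from compound 3 to compound 4 (0.12 log units; within the scatter), a change that is not expected to reach beyond the scatter in either direction. On that basis compound 4 is estimated at 1500 nM, with a range from 500 nM to 5000 nM.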

Compound 4, half-maximal inhibitory concentration: 1400 nM
For compound 4 the middle estimate is 1.1-fold (0.03 log units) above the measured one, and the stated range covers the measured number.
By their numbers in this assay, from the lowest: compound 1; then compounds 4 and 3 (each within the scatter of the next).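

In this assay, placing 3,5-dichlorophenyl in place of 4-chlorophenyl on the oxygen gives a 1.4-fold lower number from compound 3 to compound 4 (0.15 log units; within the scatter). Within the data shown here, this is the first measured step in the set at any position, and it shows that this end of the molecule can take a second chlorine and a different chlorine pattern with no change that stands clear of the ordinary variation between repeat measurements. There is no measured information on why the swap makes so little difference, so the result stands as an observation without an explanation.

The step changes the number of chlorines and their placement together, so the compounds shown leave open what each of these does alone, and a flat result for this one swap says little about less similar replacements. On these data alone, whether a plain phenyl, a methoxyphenyl, a pyridine ring or a phenyl carrying an amine or a carboxylic acid on the same oxygen would shift the number beyond that variation also remains open.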